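The compounds below may be only part of what the source reports. "The series", "measured", "known", "first", "only" and "open" are said of these compounds alone.

Working notes on the series.

Compound 1 `CCOC(=O)Nc1cc2c(c(N)n1)N=C(c1ccccc1)CO2` carries a plain phenyl on its core; in a functional assay on L1210 cells (Mus musculus) for antiproliferative activity, with a stated time of 48 h (a lower number here means a stronger inhibitor, a higher number a weaker inhibitor), compound 1 gives 0.225 uM. Compound 2 `CCOC(=O)Nc1cc2c(c(N)n1)N=C(c1cccc(OC)c1)CO2` differs from compound 1 by methoxy in place of hydrogen on an aromatic carbon and in this assay compound 2 gives 0.052 uM; the step is a 4.3-fold lower number from compound 1 to compound 2 (0.64 log units; beyond the scatter). Compound 3 `CCOC(=O)Nc1cc2c(c(N)n1)N=C(c1ccccc1)CS2` is built on a different core, and the difference between the two cores is not broken down here. In this assay compound 3 gives 6.1 uM, the highest of the three numbers, with compound 1 nearest and compound 2 furthest.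

Compound 4 `CCOC(=O)Nc1cc2c(c(N)n1)N=C(c1cccc(OC)c1)CS2` is not yet measured. It differs from compound 3 by methoxy in place of hydrogen on an aromatic carbon, which is the same change as that from compound 1 to compound 2, occurring twice in all among these compounds; the place of the change reads the same in both pairs. The change has been read only once, on the core of compound 1, so its transfer to the core of compound 3 rests on a single pair and carries some uncertainty. The expected step is a 3.8-fold lower number from compound 3 to compound 4 (0.58 log units; beyond the scatter), set close to but a little short of a 4.3-fold lower number from compound 1 to compound 2 (0.64 log units; beyond the scatter). In this assay compound 4 is expected to give about 1.6 uM, with the likely range from 0.5 uM to 4.5 uM.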

Compound 4, concentration for 50% inhibition: 0.53 uM
For compound 4 the middle estimate is 3.0-fold (0.48 log units) above the measured one, and the stated range covers the measured number.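

In this assay, the change from phenyl to 3-methoxyphenyl again gives a lower number on the core of compound 3, where the step is a 12-fold lower number from compound 3 to compound 4 (1.06 log units; beyond the scatter), so the direction read on the core of compound 1 carries over to this second core. The two steps cannot be told apart in size, and the larger figure on the second core gives no ground for saying that this core responds more strongly to the change: the same change on two cores in this assay, a 4.3-fold lower number (0.64 log units; beyond the scatter) from compound 1 to compound 2 and a 12-fold lower number (1.06 log units; beyond the scatter) from compound 3 to compound 4, 2.7-fold (0.42 log units) apart, within the scatter of two such steps. Within the data shown here, this shows only that one change, at one place on the aromatic ring, moves the same way on two cores; two pairs in a single assay do not establish a fixed step size, nor do they show that the change would carry to any further core.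

The compounds shown leave open whether another group at the same place, such as an amine, a carboxylic acid or a longer alkoxy chain, would move the number in the same way on both cores. They also leave open whether methoxy elsewhere on the aromatic ring would behave as it does here, and what in the difference between the two cores governs the numbers.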